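The compounds below may be only part of what the source reports. "The series", "measured", "known", "first", "only" and "open" are said of these compounds alone.

Of the compounds shown here, two have been measured in a functional assay on HT-29 cells (Homo sapiens) for cytotoxicity, read by MTT assay, with a stated time of 72 h (a higher number here means a weaker inhibitor of growth, a lower number a stronger inhibitor of growth), so far, and both share one core. Compound 1 `C[Se]c1nc(N)c2ccccc2n1` gives 27600 nM, and compound 2 `Nc1nc([SeH])nc2ccccc12` gives 52200 nM. Within the data shown here, the single change between them, a 1.9-fold higher number from compound 1 to compound 2 (0.28 log units; within the scatter), leaves the pair inseparable by this measurement: compound 1 stands beside compound 2 rather than apart from it. Compound 3 `C[Se]c1nc([Se]C)c2ccccc2n1` differs from compound 1 in a group of 2 heavy atoms (1 carbon, 1 selenium; no ring) in place of one nitrogen atom, on an aromatic carbon. Among the measured compounds shown here, no measured step bears on this exchange; the only step known alters what sits on the selenium and leaves the amino group untouched, so it offers no guide to direction or size. With nothing more to lean on than the two values, the step of a 1.1-fold higher number from compound 1 to compound 3 (0.04 log units; within the scatter) is expected to be none beyond the scatter, and the range is kept wide for that reason. Compound 3 is therefore expected at 30000 nM, with a range from 7000 nM to 120000 nM.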

Compound 3, concentration for 50% growth inhibition: 7460 nM
Compound 3: middle estimate off by 4.0-fold (0.60 log units), on the high side, within the range that was stated.
By their numbers in this assay, from the lowest: compound 3; then compounds 1 and 2 (each within the scatter of the next).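

In this assay, the amino group on this aromatic carbon can give way to a methyl on a selenium without loss of growth inhibition: the exchange gives a 3.7-fold lower number from compound 1 to compound 3 (0.57 log units; beyond the scatter), a modest step. Unlike the earlier change on the selenium of compound 1, this step stands clear of the usual scatter, so this position responds to the group it carries. Nothing available explains the step.

The compounds shown leave open how much of the step belongs to the selenium and how much to the methyl on it; a methoxy or methylthio group on this carbon would help separate the two. Also open, as far as these compounds go, is how a longer chain on this selenium, such as ethyl or butyl, would read in this assay.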